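Cyclopropane-fused core and the 2-fluorophenyl swap in microsomes

A few compounds are considered here, and "the series" means these few. Any claim that something is new, unique, unknown or untested is made for them only; others in the source may bear on it.

Measured compounds:
compound 1, `O=C(NCc1cc(Cl)ccc1-n1cnnn1)[C@@H]1CC=NN1C(=O)[C@H](O)c1ccccc1F`: 16 mL.min-1.g-1
compound 2, `CC1(C[C@@H](O)C(=O)N2N=CC[C@H]2C(=O)NCc2cc(Cl)ccc2-n2cnnn2)CC1`: limit, < 12 mL.min-1.g-1
compound 3, `CC1(C[C@@H](O)C(=O)N2C[C@H]3C[C@H]3[C@H]2C(=O)NCc2cc(Cl)ccc2-n2cnnn2)CC1`: 12 mL.min-1.g-1

In an ADME assay on liver for metabolic stability, with Liver microsome (Homo sapiens) as the target, read by LC-MS, using microsomes (a higher number here means faster removal of the compound, a lower number slower removal), compound 1 gives 16 mL.min-1.g-1. In this assay compound 2 gives only a limit, < 12 mL.min-1.g-1, and the limit is the limit of < 12 mL.min-1.g-1 in this assay, at which 1 of the 3 values shown sits. Compound 3 gives 12 mL.min-1.g-1 in this assay; its value and that of compound 1 sit within the scatter of each other. The difference between the cores of compound 2 and compound 3 is not broken down here.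

The change from compound 2 to compound 1 is 2-fluorophenyl in place of (1-methylcyclopropyl)methyl on a saturated chain carbon bound to a carbonyl carbon and an oxygen on a saturated carbon, and it gave an at least 1.3-fold higher number from compound 2 to compound 1 (0.12 log units; that floor lies within the scatter). The same kind of change, (2-fluorophenyl in place of (1-methylcyclopropyl)methyl on a saturated chain carbon bound to a carbonyl carbon and an oxygen on a saturated carbon), leads from compound 3 to compound 4, `O=C(NCc1cc(Cl)ccc1-n1cnnn1)[C@@H]1[C@@H]2C[C@@H]2CN1C(=O)[C@H](O)c1ccccc1F`, which has not been measured in this assay. Because the step of an at least 1.3-fold higher number from compound 2 to compound 1 (0.12 log units; that floor lies within the scatter) has a floor that lies within the scatter, compound 4 is expected to move little from compound 3, with an estimated step of a 1.3-fold higher number from compound 3 to compound 4 (0.12 log units; within the scatter). For compound 4 in this assay an intrinsic clearance of 16 mL.min-1.g-1 is expected, between 9 mL.min-1.g-1 and 28 mL.min-1.g-1.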

Compound 4, intrinsic clearance in microsomes: < 12 mL.min-1.g-1
Compound 4 was reported as a limit; the forecaster's own chance of this, stated with the estimate: 20%; middle value at least 1.3-fold (0.12 log units) from the limit.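

In this assay, putting 2-fluorophenyl in place of (1-methylcyclopropyl)methyl gave a number no higher from compound 3 to compound 4 (the limit leaves the size open). Set beside the same change on the other core, the two steps can be neither matched nor separated: the same change on two cores in this assay, an at least 1.3-fold higher number (0.12 log units; that floor lies within the scatter) from compound 2 to compound 1 and a number no higher (the limit leaves the size open) from compound 3 to compound 4; the limit leaves it open whether they differ

This shows that the change brought no rise in the number on the core of compound 3. It does not show whether the change carries from one core to the other with the same size, as the values of compound 2 and compound 4 rest at a single limit: the limit of < 12 mL.min-1.g-1 in this assay, at which 2 of the 4 values shown sit.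

The compounds shown leave open how the position on the saturated chain carbon would read with a group other than these two, such as an amine, a carboxylic acid or a longer chain. They also leave open what numbers compound 2 and compound 4 would carry, as each is reported only as a limit.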